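A few compounds are considered here, and "the series" means these few. Any claim that something is new, unique, unknown or untested is made for them only; others in the source may bear on it.

Working notes on a short series built on the core of compound 1 `Cn1nnnc1SCC(=O)N/N=C/c1ccccc1`. In an ADME assay on NIH3T3 cells (Mus musculus) for cytotoxicity, read by XTT assay, with a stated time of 24 h (on this read-out higher numbers stand for weaker inhibition and lower numbers for stronger inhibition), compound 1 gives 9700000 nM. Compound 2 `Cn1nnnc1SCC(=O)N/N=C/c1ccc([N+](=O)[O-])cc1` gives 9300000 nM in this assay. Compound 3 `Cn1nnnc1SCC(=O)N/N=C/c1ccc(C(F)(F)F)cc1` returns only a limit of the assay, > 10000000 nM in this assay; that reading is the limit of > 10000000 nM in this assay, at which 1 of the 3 values shown sits. Among the two numbers, compound 1 stands highest, with compound 2 nearest. The step of a 1.0-fold lower number from compound 1 to compound 2 (0.02 log units; within the scatter) goes with nitro in place of hydrogen on an aromatic carbon; the step of an at least 1.0-fold higher number from compound 1 to compound 3 (0.01 log units; that floor lies within the scatter) goes with trifluoromethyl in place of hydrogen on an aromatic carbon; and an at least 1.0-fold higher number from compound 2 to compound 3 (0.03 log units; that floor lies within the scatter) goes with trifluoromethyl in place of nitro on an aromatic carbon. None of these moves the read-out beyond the scatter.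

Compound 4 `Cn1nnnc1SCC(=O)N/N=C/c1ccccc1F` differs from compound 1 by fluoro in place of hydrogen on an aromatic carbon, the new group sitting ortho to a large group. Going by the values given here, no measured step introduces fluoro, but the two substitutions on the same aromatic ring, a 1.0-fold lower number from compound 1 to compound 2 (0.02 log units; within the scatter) and an at least 1.0-fold higher number from compound 1 to compound 3 (0.01 log units; that floor lies within the scatter), both stayed within the scatter, and therefore no step beyond the scatter is expected in this assay in either direction; the expected step is no change at the digits printed from compound 1 to compound 4 (within the scatter). Compound 4 is accordingly estimated at 9700000 nM, with a range from 5000000 nM to 20000000 nM, and a real chance that only a limit is returned.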

Compound 4, half-maximal inhibitory concentration: 2000000 nM
Estimate against measurement, compound 4: 4.9-fold (0.69 log units) above; measured number below the stated range.
By their numbers in this assay, from the lowest: compound 4; then compounds 2 and 1 (each within the scatter of the next). At a limit, above all of these: compound 3.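

In this assay, going by these compounds alone, fluoro in place of hydrogen on an aromatic carbon, ortho to a large group, is the first change to move the read-out beyond the scatter, with a 4.9-fold lower number from compound 1 to compound 4 (0.69 log units; beyond the scatter) as the modest step. The single fluorine is only 1 heavy atom, so a change of this small size on the aromatic ring of the shared core is enough to register, whereas the nitro of compound 2 on that ring gave no step beyond the scatter from compound 1. Within the data shown here, compound 3 still returns only a limit of the assay, so its trifluoromethyl change gives no sized step to set against the fluoro step: (the limit of > 10000000 nM in this assay, at which 1 of the 4 values shown sits).

The compounds shown leave open whether the step belongs to fluoro itself or to any group placed ortho to a large group; a chloro, a methoxy or an amine on that carbon would separate the two. Also open, on these data alone, is whether fluoro keeps this step when a nitro or a trifluoromethyl stands on the same ring.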